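Will compound 4 stay at the limit?

The source may report more compounds than this note shows. Statements on the series, on what has been measured and on what is new or still open speak of the compounds shown alone.

In a functional assay on HEK293 cells (Homo sapiens) for cytotoxicity (a higher number here means that more compound is tolerated, a lower number that less compound is tolerated), compound 1 (`COc1ccc([C@H]2CC(=O)N(c3cc(N)cc(N)c3)C2)cc1OC1CCCC1`) gives > 10000 nM as a limit, not a number. Compound 2 (`COc1ccc([C@H]2CC(=O)N(c3ccc(C)c(N)c3)C2)cc1OC1CCCC1`) gives > 10000 nM as a limit as well. Compound 3 (`COc1ccc([C@H]2CC(=O)N(c3cc(N)cc(F)c3)C2)cc1OC1CCCC1`) gives > 10000 nM as a limit too. Compound 3 therefore stands with the other two, at the limit of > 10000 nM in this assay, at which 3 of the 3 values shown sit, so far, and no order among them can be read.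

Compound 4 (`COc1ccc([C@H]2CC(=O)N(c3cccc(C)c3)C2)cc1OC1CCCC1`) carries 3-methylphenyl in place of 3-amino-5-fluorophenyl on an amide-type nitrogen in a ring, with 3-methylphenyl in place of 3-amino-5-fluorophenyl on an amide-type nitrogen in a ring as the full count of the change.

For the measured compounds named here, three measured steps bear on this swap: a step that the two limits leave unreadable from compound 1 to compound 2 and a step that the two limits leave unreadable from compound 1 to compound 3 and also a step that the two limits leave unreadable from compound 2 to compound 3 (none has a readable size). They offer no direction, and the expectation rests only on all three compounds sitting at that same limit.

The expected move is a step that the limit leaves unreadable from compound 3 to compound 4 and no step beyond the usual scatter is expected. Compound 4 is estimated at 15000 nM in this assay, with an expected range from 8000 nM to 40000 nM and a good chance of being reported only as a limit.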

Compound 4, half-maximal cytotoxic concentration: > 10000 nM
Compound 4 was reported as a limit (the forecaster's own chance of this, stated with the estimate: 90%); the middle value is on the limit's open side.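

Compounds 1, 2, 3 and 4 all sit at one limit, so no step among them, including those to compound 4, can be read: the limit of > 10000 nM in this assay, at which 4 of the 4 values shown sit.

The compounds shown leave open at what concentration any of them becomes toxic to these cells, and whether their different groups on the amide-type nitrogen matter at all.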